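Prostacyclin synthase series: aryloxy variation on the shared core

The source may hold more compounds than are shown below. What is called first, only, known or untested is meant among the compounds shown, and "the series" means these compounds.

Measured so far:
compound 1, `COc1ccc(OC(C)(C)C2OCC(C/C=C\CCC(=O)O)C(c3cccnc3)O2)cc1`, > 100000 nM
compound 2, `Cc1ccc(OC(C)(C)C2OCC(C/C=C\CCC(=O)O)C(c3cccnc3)O2)cc1`, 25000 nM

In an assay for inhibition of prostacyclin synthase (Homo sapiens), using microsomes (on this read-out higher numbers stand for weaker inhibition and lower numbers for stronger inhibition), compound 1 gives > 100000 nM, which is a limit of the assay and not a number. In this assay, among the compounds with values here, compound 2 gives 25000 nM, the only number so far among the two values shown. Within the data shown here, the measured step of an at least 4.0-fold lower number from compound 1 to compound 2 (0.60 log units; beyond the scatter) is the single piece of evidence on this part of the structure; it rests on the limit of > 100000 nM in this assay, at which 1 of the 2 values shown sits, and so gives only a lower bound of its size.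

Compound 3, `CSc1ccccc1OC(C)(C)C1OCC(C/C=C\CCC(=O)O)C(c2cccnc2)O1`, is not yet measured. It differs from compound 2 by 2-(methylsulfanyl)phenyl in place of 4-methylphenyl on an oxygen on a saturated carbon. Among the measured compounds shown here, no measured step covers this change: the methyl-for-methoxy step touches the same aryl group but not the same substituent or the same kind of swap, so it gives no direction. The expectation is a step of no change at the digits printed from compound 2 to compound 3 (within the scatter), that is, no change beyond the scatter. Compound 3 is therefore estimated at 25000 nM, with a range from 5000 nM to 100000 nM.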

Compound 3, half-maximal inhibitory concentration: > 100000 nM
Compound 3 gave a limit, no number; the forecaster's own chance of this, stated with the estimate: 25%; middle value at least 4.0-fold (0.60 log units) away from the limit.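

In this assay, 2-(methylsulfanyl)phenyl in place of 4-methylphenyl on the oxygen gives an at least 4.0-fold higher number from compound 2 to compound 3 (0.60 log units; beyond the scatter), so the 4-methylphenyl result does not carry over to this other substituted aryl group. Compound 3 gives > 100000 nM, which is a limit of the assay and not a number. Within the data shown here, compound 2 therefore remains the only compound of the three with a number, the size of the new step is only a lower bound, and the step between compound 1 and compound 3 cannot be read: the limit of > 100000 nM in this assay, at which 2 of the 3 values shown sit.

This step changes both the substituent and its place on the aryl ring, so the compounds shown do not separate those two changes. Also open, on these data alone, is whether an amine or a chlorine on that ring would give a number in this assay.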